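Methyl Added to the Sulfonyl Phenyl Ring

The source may report more compounds than this note shows. Statements on the series, on what has been measured and on what is new or still open speak of the compounds shown alone.

Measured so far in a functional assay on QGY-7703 cells (Homo sapiens) for cytotoxicity, read by MTT assay, with a stated time of 24 h; a higher number here means a weaker inhibitor, a lower number a stronger inhibitor:
- compound 1, `O=C1/C(=C/c2cccnc2)CN(S(=O)(=O)c2ccccc2)C/C1=C\c1ccccc1F`, gives 4800 nM
- compound 2, `Cc1ccc(S(=O)(=O)N2C/C(=C\c3cccnc3)C(=O)/C(=C/c3ccccc3F)C2)cc1`, gives 9700 nM
- compound 3, `O=C1/C(=C/c2ccncc2)CN(S(=O)(=O)c2ccccc2)C/C1=C\c1ccccc1F`, gives 8400 nM

Compound 4, `Cc1ccc(S(=O)(=O)N2C/C(=C\c3ccncc3)C(=O)/C(=C/c3ccccc3F)C2)cc1`, has not yet been measured in this assay. It differs from compound 3 by one change: methyl in place of hydrogen on an aromatic carbon. The same change, at the same place, connects two measured compounds, compound 1 and compound 2: methyl in place of hydrogen on an aromatic carbon. That step gave a 2.0-fold higher number from compound 1 to compound 2 (0.31 log units; beyond the scatter). The two cores on which the change is made differ from each other as well: pyridin-4-yl in place of pyridin-3-yl on a double-bonded chain carbon bound to a double-bonded ring carbon, a difference that gave a 1.8-fold higher number from compound 1 to compound 3 (0.24 log units; within the scatter).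

Among the compounds with values here, with only one measured example of the change, the expectation for compound 4 rests on it alone. A step of similar size is expected from compound 3 to compound 4, namely a 1.9-fold higher number from compound 3 to compound 4 (0.28 log units; within the scatter), because the same change gave a 2.0-fold higher number from compound 1 to compound 2 (0.31 log units; beyond the scatter) on a closely related core. The estimate for compound 4 in this assay is therefore 16000 nM, expected to lie between 8000 nM and 32000 nM.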

Compound 4, half-maximal inhibitory concentration: > 20000 nM
Compound 4: only a limit was reported; the forecaster's own chance of this, stated with the estimate: 10%; at least 1.2-fold (0.09 log units) between middle value and limit.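

In this assay compound 4 gives > 20000 nM, which is a limit of the assay and not a number. Turning phenylsulfonyl into (4-methylphenyl)sulfonyl gives an at least 2.3-fold higher number from compound 3 to compound 4 (0.37 log units; beyond the scatter), so the methyl raises the number on this core as it did on the core of compound 1, showing that the direction of the change carries over, while its exact size on the second core stays unknown: the same change on two cores in this assay, a 2.0-fold higher number (0.31 log units; beyond the scatter) from compound 1 to compound 2 and an at least 2.3-fold higher number (0.37 log units; beyond the scatter) from compound 3 to compound 4; the limit leaves it open whether they differ. The same caution applies to the other change in the square of compounds, pyridin-4-yl in place of pyridin-3-yl, which with the methyl present gives an at least 2.0-fold higher number from compound 2 to compound 4 (0.31 log units; beyond the scatter): the same change on two cores in this assay, a 1.8-fold higher number (0.24 log units; within the scatter) from compound 1 to compound 3 and an at least 2.0-fold higher number (0.31 log units; beyond the scatter) from compound 2 to compound 4; the limit leaves it open whether they differ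

The compounds shown leave open how far the true number for compound 4 lies past its limit, and so whether the methyl costs more on one core than on the other. They also leave open how an ethyl or a methoxy group on that same aromatic carbon would compare, and whether the methyl step would hold on a core carrying pyridin-2-yl.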